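Amide nitrogen: phenyl replaced by 3-phenylpropyl

The compounds below may be only part of what the source reports. "The series", "measured", "known", "first", "only" and "open" are said of these compounds alone.

Compound 2 `CCCSc1nc(Cl)c2c(n1)N(Cc1ccccc1)C(C(=O)Nc1ccccc1)N2` is the reference point of this step. Among the measured compounds shown here, in a functional assay on MGC-803 cells (Homo sapiens) for antiproliferative activity, read by MTT assay, with a stated time of 72 h (on this read-out lower numbers stand for stronger inhibition and higher numbers for weaker inhibition), compound 2 gives 58400 nM, the only number so far. Compound 1 `CCCSc1nc(Cl)c2c(n1)N(Cc1ccccc1)C(C(=O)O)N2` is reported in this assay only as a limit, > 64000 nM. For the measured compounds named here, the single measured step, an at least 1.0-fold lower number from compound 1 to compound 2 (0.03 log units; that floor lies within the scatter), rests on that limit (the limit of > 64000 nM in this assay, at which 1 of the 2 values shown sits) and lies within the scatter, so it sets no direction for the series.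

Compound 3 `CCCSc1nc(Cl)c2c(n1)N(Cc1ccccc1)C(C(=O)NCCCc1ccccc1)N2` differs from compound 2 by 3-phenylpropyl in place of phenyl on an amide-type nitrogen. Going by the values given here, no measured step touches this change: the step from compound 1 to compound 2 altered what hangs on the carbonyl carbon rather than the substituent on the amide nitrogen, and its size is bounded by a limit only. In this assay the expectation is therefore no movement beyond the scatter, and compound 3 is estimated at 50000 nM with a range of 20000 nM to 120000 nM. The expected step is a 1.2-fold lower number from compound 2 to compound 3 (0.07 log units; within the scatter). Since the number for compound 2 sits close to the assay limit, compound 3 may be reported as a limit rather than a value.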

Compound 3, half-maximal inhibitory concentration: 16900 nM
Compound 3: middle estimate off by 3.0-fold (0.47 log units), on the high side; measured number outside the range, below it.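

In this assay, among the compounds shown here, 3-phenylpropyl in place of phenyl on the amide-type nitrogen gives the first step that clearly lies beyond the scatter (a 3.5-fold lower number from compound 2 to compound 3 (0.54 log units; beyond the scatter)), so the substituent at this nitrogen is a place where the read-out responds, whereas the earlier step on the carbonyl carbon set no direction. The two groups carry the same aromatic ring and the same hydrogen-bond donor and acceptor counts, and the listed difference lies in carbon alone, with 9 heavy atoms entering and 6 leaving. The step from the carboxylic acid (an at least 3.7-fold lower number from compound 1 to compound 3 (0.57 log units; beyond the scatter)) also lies beyond the scatter, but its size is only a floor, and compound 1 is reported as a limit: the limit of > 64000 nM in this assay, at which 1 of the 3 values shown sits.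

From the compounds shown here alone, one pair gives no trend, so it remains open whether the number follows chain length, which benzyl or 2-phenylethyl on the same nitrogen would test. Going by these compounds, it also remains open whether the aromatic ring of the 3-phenylpropyl group is needed at all, a question that a plain propyl chain or a chain ending in an amine would address.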